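Acetyl to Dimethylamino: an Expected Gain in Cell Activity

This account rests on a few compounds, and the source may have more. Where it says the series, first, only, none or still open, it means among the compounds named here.

Of the compounds shown here, three built on one shared core have been tested in a functional assay on MCF7 cells (Homo sapiens) for cytotoxicity, read by sulforhodamine B assay, with a stated time of 48 h, tested at 0.01 uM; on this read-out higher numbers stand for a weaker effect at the one concentration tested and lower numbers for a stronger effect. Compound 1 `COc1cc(C)cc(-c2c(-c3ccnc(-c4ccc(C(C)=O)cc4)c3)cnn2CC#N)c1` gives 92% and stands second highest of the three. Compound 2 `COc1cc(C)cc(-c2nn(CC#N)cc2-c2ccc(-c3cccc(C(C)=O)c3)nc2)c1` gives 97%, within the usual scatter of compound 1. Compound 3 `COc1cc(C)cc(-c2nn(CC#N)cc2-c2ccnc(-c3ccc(N(C)C)cc3)c2)c1`, which carries a dimethylamino group, gives 38%, well below the other two. Compound 4 `COc1cc(C)cc(-c2c(-c3ccnc(-c4ccc(N(C)C)cc4)c3)cnn2CC#N)c1` has not been measured; it differs from compound 1 in one place: dimethylamino in place of acetyl on an aromatic carbon. Within the data shown here, no pair of measured compounds covers this exact change. A move toward a stronger effect is expected because compound 3 gives 38% with the same entering group. The expected step of a number 47 percentage points lower from compound 1 to compound 4 (beyond the scatter) is therefore downward and beyond the scatter. Compound 4 is estimated at 45%, within 25% to 72%.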

Compound 4, a percentage reported as activity, at one concentration (the size of the read-out at that concentration, not a potency): 56%
Estimate against measurement, compound 4: 11 percentage points below, within the range that was stated.
By their numbers in this assay, from the lowest: compound 3; then compound 4; then compounds 1 and 2 (each within the scatter of the next).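

In this assay, dimethylamino in place of acetyl, on an aromatic carbon para to a large group, gives a number 36 percentage points lower from compound 1 to compound 4 (beyond the scatter). Among these compounds, no earlier pair differed in this one place alone, so this pair is the first to show the change by itself, and it shows a stronger effect at the one concentration tested.

Nothing available here explains the size or direction of this step. Going by these compounds, whether a plain amino group, a morpholine or a carboxylic acid at this place would give a similar read-out remains open.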